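Acetamido to (Ethylcarbamoyl)amino: An Unmeasured Step

The compounds below may be only part of what the source reports. "The series", "measured", "known", "first", "only" and "open" are said of these compounds alone.

Of the compounds shown here, three sharing one core have been tested in a functional assay on WI-38 VA13 cells (Homo sapiens) for cytotoxicity; on this read-out lower numbers stand for an effect already at smaller amounts and higher numbers for an effect only at larger amounts of compound. Compound 1 `O=C(Nc1ccc2nc(NC(=O)C3CCCCC3)sc2c1)c1cccc(Oc2ccccc2)c1` reaches only the limit > 4 ug/mL there. Compound 2 `C=CCOC(=O)Nc1ccc2nc(NC(=O)C3CCCCC3)sc2c1` gives 0.58 ug/mL in this assay. Compound 3 `CC(=O)Nc1nc2ccc(NC(=O)c3c(Cl)cccc3Cl)cc2s1` gives 0.6 ug/mL in this assay; it holds the higher of the two numbers, but its gap to compound 2 lies within the usual scatter, so the two cannot be told apart. Compound 4 `CCNC(=O)Nc1nc2ccc(NC(=O)c3c(Cl)cccc3Cl)cc2s1` has not yet been measured. It differs from compound 3 in one place: ethylamino in place of methyl on a carbonyl carbon. Going by the values given here, no measured pair shows this change, so the data give no direct guide to its size. The expected step is small, not beyond the scatter, a 1.3-fold higher number from compound 3 to compound 4 (0.12 log units; within the scatter). Compound 4 is accordingly estimated at 0.8 ug/mL in this assay, within a range from 0.3 ug/mL to 2.5 ug/mL.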

Compound 4, half-maximal effective concentration: 0.032 ug/mL
Estimate against measurement, compound 4: 25-fold (1.40 log units) above; measured number outside the range, below it.
By their numbers in this assay, from the lowest: compound 4; then compounds 2 and 3 (each within the scatter of the next). At a limit, above all of these: compound 1.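

Ethylamino in place of methyl on a carbonyl carbon gives a 19-fold lower number from compound 3 to compound 4 (1.27 log units; beyond the scatter) in this assay. Going by these compounds alone, the earlier compounds included no measured pair that differed at this place, so this is the first sign that the number responds strongly to a change there. No measurement shown gives a cause for this step. Going by these compounds, it remains open whether methylamino, a longer chain such as butylamino, or a ring amine such as morpholine on this carbonyl carbon would give a similar number. Whether the oxygen-linked ethoxy group would do the same also stays unanswered.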